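The source may hold more compounds than are shown below. What is called first, only, known or untested is meant among the compounds shown, and "the series" means these compounds.

For the measured compounds named here, in a functional assay on MCF7 cells (Homo sapiens) for cytotoxicity, read by MTT assay, with a stated time of 96 h (a higher number here means a weaker inhibitor, a lower number a stronger inhibitor), compound 2 `COc1cc(C(=O)c2cn(-c3ccccc3)cc2-c2cccc([N+](=O)[O-])c2)cc(OC)c1OC` gives 50 nM, the lowest number of the three measured so far. Compound 1 `COc1cc(C(=O)c2cn(-c3ccccc3)cc2-c2ccc(Cl)cc2)cc(OC)c1OC` gives 290 nM and compound 3 `COc1cccc(-c2cn(-c3ccccc3)cc2C(=O)c2cc(OC)c(OC)c(OC)c2)c1` gives 180 nM. Both stand beyond the scatter from compound 2, as a 5.8-fold lower number from compound 1 to compound 2 (0.76 log units; beyond the scatter) and a 3.6-fold higher number from compound 2 to compound 3 (0.56 log units; beyond the scatter) show, whereas a 1.6-fold lower number from compound 1 to compound 3 (0.21 log units; within the scatter) does not exceed it.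

Compound 4 `COc1cc(C(=O)c2cn(-c3cccc(C)c3)cc2-c2cccc([N+](=O)[O-])c2)cc(OC)c1OC` differs from compound 2 by methyl in place of hydrogen on an aromatic carbon, phenyl to 3-methylphenyl: methyl in place of hydrogen on an aromatic carbon. Going by the values given here, none of the measured steps touches that phenyl. Among the compounds with values here, they exchange 4-chlorophenyl, 3-nitrophenyl and 3-methoxyphenyl, so they offer no direct precedent and show only that single exchanges elsewhere have moved the number by modest steps or less. No step beyond the scatter is therefore expected in this assay, and no direction can be argued from these data. The expected change is a 1.2-fold higher number from compound 2 to compound 4 (0.08 log units; within the scatter). Compound 4 is estimated at 60 nM, with an expected range of 20 nM to 180 nM.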

Compound 4, half-maximal inhibitory concentration: 880 nM
The estimate for compound 4 lay 15-fold (1.17 log units) below the measured number, and the stated range ends below it.
By their numbers in this assay, from the lowest: compound 2; then compounds 3 and 1 (each within the scatter of the next); then compound 4.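

In this assay, the phenyl that had stayed constant across compound 1, compound 2 and compound 3 proves sensitive to substitution: the change to 3-methylphenyl gives an 18-fold higher number from compound 2 to compound 4 (1.25 log units; beyond the scatter). A single added methyl on this ring thus moves the number further than the largest earlier exchange at the other aryl group, a 5.8-fold lower number from compound 1 to compound 2 (0.76 log units; beyond the scatter), so this position cannot be treated as freely open to substitution when 3-nitrophenyl is present. No measurement at hand bears on the reason for this loss.

Still open, going by these compounds, is whether the loss is specific to methyl or extends to other groups at this place, such as a fluorine, a hydroxyl or an amine. Also open, on these data alone, is whether the same methyl has a similar effect alongside 4-chlorophenyl or 3-methoxyphenyl.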